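Thieno-for-furo swap on the aryl ether of compound 2

A few compounds are considered here, and "the series" means these few. Any claim that something is new, unique, unknown or untested is made for them only; others in the source may bear on it.

Measured so far:
- compound 1 `Cc1ncc2nccn2c1-c1ccc(Oc2nccc3occc23)cc1C(F)(F)F`: 8700 nM
- compound 2 `FC(F)(F)c1cc(Oc2nccc3occc23)ccc1-c1cccc2nccn12`: 7000 nM

Both numbers come from an assay on isolated protein for displacement of a labelled ligand from Alpha-1A adrenergic receptor (Homo sapiens), read by scintillation counting, with a stated time of 90 min; on this read-out lower numbers stand for stronger inhibition and higher numbers for weaker inhibition. Compound 2 stands at 7000 nM, and compound 1 sits within the scatter of it: the step of a 1.2-fold lower number from compound 1 to compound 2 (0.09 log units; within the scatter) does not separate the two. Compound 2 is therefore the reference point, with no ranking possible among the measured pair.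

Compound 3 `FC(F)(F)c1cc(Oc2nccc3ccsc23)ccc1-c1cccc2nccn12` is not yet measured in this assay. It differs from compound 2 in one place: a group of 9 heavy atoms (7 carbon, 1 nitrogen, 1 sulfur; one five-membered aromatic ring with 1 hetero atom, one six-membered aromatic ring with 1 hetero atom) in place of a group of 9 heavy atoms (7 carbon, 1 nitrogen, 1 oxygen; one five-membered aromatic ring with 1 hetero atom, one six-membered aromatic ring with 1 hetero atom), on an oxygen on an aromatic ring. Among the compounds with values here, the only measured step, from compound 1 to compound 2, concerns the bicyclic group on the other aryl carbon and says nothing about the ether-linked bicyclic group; no measured step bears on the exchange made here. With no shown step pointing either way, no change beyond the scatter is expected, and the estimated step of a 1.2-fold lower number from compound 2 to compound 3 (0.07 log units; within the scatter) reflects that. From the compounds shown here alone, for compound 3 the expected value in this assay is 6000 nM, with a range from 2000 nM to 20000 nM, a wide range because the exchange is untested.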

Compound 3, inhibition constant: 2900 nM
For compound 3 the middle estimate is 2.1-fold (0.32 log units) above the measured one; the measured number falls inside the stated range.
By their numbers in this assay, from the lowest: compound 3; then compounds 2 and 1 (each within the scatter of the next).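

In this assay, within the data shown here, replacing the group on the oxygen on an aromatic ring gives the only step that lies beyond the scatter (a 2.4-fold lower number from compound 2 to compound 3 (0.38 log units; beyond the scatter)), whereas the exchange on an aromatic carbon did not separate its pair (a 1.2-fold lower number from compound 1 to compound 2 (0.09 log units; within the scatter)). This position therefore responds to an exchange of one oxygen for one sulfur, even though the two groups match in heavy atom count, ring types, hydrogen-bond donors, hydrogen-bond acceptors and net charge. Nothing available accounts for the lower number in compound 3.

From the compounds shown here alone, whether the same exchange lowers the number on the core of compound 1 remains open, and a single pair cannot show whether the effect at this position is general. Also open, going by these compounds, is how the position responds to groups of a different kind, such as a plain phenyl in place of the bicyclic group, or a primary amine or a carboxylic acid carried on it.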